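The compounds below may be only part of what the source reports. "The series", "measured", "known", "first", "only" and "open" are said of these compounds alone.

Working notes on a small set: compound 1 `COc1cc2c(cc1O)C(=O)CC(C(=O)O)O2`, compound 2 `CCCCNC(=O)C1CCc2cc(O)c(OC)cc2O1`, compound 3 `CCCCNC(=O)C1CC(=O)c2cc(O)c(OC)cc2O1` and compound 4 `COc1cc2c(cc1O)CCC(C(=O)O)O2` share a core; the difference between the cores of compound 2 and compound 3 is not broken down here. In a functional assay (brain) for inhibition, with Rattus norvegicus as the target (on this read-out higher numbers stand for weaker inhibition and lower numbers for stronger inhibition), compound 2 gives 51300 nM, the lower of the two numbers measured, and compound 3 gives 177000 nM. Compound 1 reaches only the limit of this assay, > 300000 nM, which is not a number (the limit of > 300000 nM in this assay, at which 1 of the 3 values shown sits).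

One change is seen twice. From compound 3 to compound 1 it reads (hydroxy in place of butylamino on a carbonyl carbon), and in this assay it gave an at least 1.6-fold higher number from compound 3 to compound 1 (0.22 log units; that floor lies within the scatter). The same change, (hydroxy in place of butylamino on a carbonyl carbon), now leads from compound 2 to compound 4, at the same place. Compound 4 is not yet measured.

For compound 4 the expected step in this assay is a 3.9-fold higher number from compound 2 to compound 4 (0.59 log units; beyond the scatter), a weakening, because the same change gave an at least 1.6-fold higher number from compound 3 to compound 1 (0.22 log units; that floor lies within the scatter) and because compound 2 starts from 51300 nM. Compound 4 is therefore estimated at 200000 nM, expected between 70000 nM and 600000 nM, with a real chance that only a limit is returned.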

Compound 4, half-maximal inhibitory concentration: > 300000 nM
Compound 4 ended at the assay's limit; the forecaster's own chance of this, stated with the estimate: 35%; at least 1.5-fold (0.17 log units) between middle value and limit.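

In this assay hydroxy in place of butylamino on a carbonyl carbon gives an at least 5.8-fold higher number from compound 2 to compound 4 (0.76 log units; beyond the scatter) and so weakens inhibition clearly on this core. The same change also ends at a limit on the other core, but the two steps are floors and their sizes cannot be set against each other: the same change on two cores in this assay, an at least 1.6-fold higher number (0.22 log units; that floor lies within the scatter) from compound 3 to compound 1 and an at least 5.8-fold higher number (0.76 log units; beyond the scatter) from compound 2 to compound 4; the limit leaves it open whether they differ. The carry-over is therefore firm in direction only for the core of compound 2, and no size can be transferred from one core to the other, since both products rest on a limit and not on a number: the limit of > 300000 nM in this assay, at which 2 of the 4 values shown sit.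

The compounds shown leave open whether the gain over hydroxy comes from the amide nitrogen or from the butyl chain, which a methylamino group or a longer chain on the same carbonyl carbon would separate. They also leave open whether an ester in that place would behave like butylamino or like hydroxy.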